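One amide swap in a series at the assay limit

The source may report more compounds than this note shows. Statements on the series, on what has been measured and on what is new or still open speak of the compounds shown alone.

- Compound 1 (`C#CC(C)OC(=O)c1ccc(C(CC)(CC)c2ccc(OCCC(O)(CC)CC)c(C)c2)n1CC`) gives > 50000 nM as a limit
- Compound 2 (`CCn1c(C(=O)Nc2ccc(OC(F)(F)F)cc2)ccc1C(CC)(CC)c1ccc(OCCC(O)(CC)CC)c(C)c1`) gives > 50000 nM as a limit

In a functional assay on HepG2 cells (Homo sapiens) for antiproliferative activity, read by MTT assay, with a stated time of 48 h (a higher number here means a weaker inhibitor, a lower number a stronger inhibitor), compound 2 stands at > 50000 nM which is a limit and not a number. Compound 3 (`CCC(C)C(NC(=O)c1ccc(C(CC)(CC)c2ccc(OCCC(O)(CC)CC)c(C)c2)n1CC)C(=O)O`) differs from compound 2 in one place (1-carboxy-2-methylbutyl in place of 4-(trifluoromethoxy)phenyl on an amide-type nitrogen) with 1-carboxy-2-methylbutyl in place of 4-(trifluoromethoxy)phenyl on an amide-type nitrogen. Within the data shown here, the one measured step, also a swap on a carbonyl carbon, is a step that the two limits leave unreadable from compound 1 to compound 2 and offers no size to carry over. The evidence stops at the limit of > 50000 nM in this assay, at which 2 of the 2 values shown sit, so no step beyond the scatter is expected in this assay in either direction. The estimated move is a number no higher from compound 2 to compound 3 (the limit leaves the size open) and it has no expected direction. Compound 3 is expected at 50000 nM with an estimated range of 20000 nM to 100000 nM and is expected to sit at a limit again.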

Compound 3, half-maximal inhibitory concentration: 2620 nM
For compound 3 the middle estimate is 19-fold (1.28 log units) above the measured one; measured number outside the range, below it.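

The group on the carbonyl carbon decides whether this assay gives a readable number at all. With 1-carboxy-2-methylbutyl on the amide-type nitrogen, the data show an at least 19-fold lower number from compound 2 to compound 3 (1.28 log units; beyond the scatter), and the swap from the ester of compound 1 gives an at least 19-fold lower number from compound 1 to compound 3 (1.28 log units; beyond the scatter). Compound 3 is the only compound shown that comes off the limit: the limit of > 50000 nM in this assay, at which 2 of the 3 values shown sit.

Compound 3 brings in the carboxy group and the branched chain together, and the compounds shown do not tell which of them matters. A methyl ester in place of the carboxy group, or a plain ethyl chain on the nitrogen, would separate the two.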